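A few compounds are considered here, and "the series" means these few. Any claim that something is new, unique, unknown or untested is made for them only; others in the source may bear on it.

Compound 1 `CCO/C(O)=C1\C(COCCn2c(C)nc(C)c2C)=NC(C)=C(C(=O)OC)C1c1ccccc1Cl` gives 5.01 nM in a functional assay (aorta) with Rattus norvegicus as the target; on this read-out higher numbers stand for weaker inhibition and lower numbers for stronger inhibition.
Compound 2 `CCO/C(O)=C1\C(COCCn2cc(C(N)=O)nn2)=NC(C)=C(C(=O)OC)C1c1ccccc1Cl` gives 20 nM in this assay.
Compound 3 `CCO/C(O)=C1\C(COCCn2nncc2C(N)=O)=NC(C)=C(C(=O)OC)C1c1ccccc1Cl` gives 100 nM in this assay.

Compound 3 stands highest of the three, so it is the weakest inhibitor here, with compound 2 nearest and compound 1 furthest. Compound 4 `CCO/C(O)=C1\C(COCCn2c(N)cnc2O)=NC(C)=C(C(=O)OC)C1c1ccccc1Cl` differs from compound 3 in one place: 5-amino-2-hydroxy-1H-imidazol-1-yl in place of 5-carbamoyl-1H-1,2,3-triazol-1-yl on a saturated chain carbon, two bonds along the chain from an oxygen on a saturated carbon. Among the compounds with values here, no measured step covers exactly this swap. The nearest guides are a 20-fold higher number from compound 1 to compound 3 (1.30 log units; beyond the scatter), where an imidazolyl ring stood in place of the carbamoyl-triazolyl ring, and a 5.0-fold higher number from compound 2 to compound 3 (0.70 log units; beyond the scatter). From the compounds shown here alone, both show the 5-carbamoyl-1H-1,2,3-triazol-1-yl group of compound 3 as the weakest choice seen, so a return to an imidazolyl ring is expected to lower the number, though the new amino and hydroxy substituents are untested. For compound 4 the expected step is a 2.5-fold lower number from compound 3 to compound 4 (0.40 log units; beyond the scatter), giving an estimate of 40 nM, within 10 nM to 200 nM.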

Compound 4, half-maximal inhibitory concentration: 158 nM
Beside the measured number, compound 4's estimate is 4.0-fold (0.60 log units) below it; measured number inside the range.
By their numbers in this assay, from the lowest: compound 1; then compound 2; then compounds 3 and 4 (each within the scatter of the next).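

The swap gives a 1.6-fold higher number from compound 3 to compound 4 (0.20 log units; within the scatter) in this assay and so separates neither group at this position. An imidazolyl ring alone does not bring the low number back, as a 32-fold higher number from compound 1 to compound 4 (1.50 log units; beyond the scatter) and a 7.9-fold higher number from compound 2 to compound 4 (0.90 log units; beyond the scatter) both show for 5-amino-2-hydroxy-1H-imidazol-1-yl against the groups of those two compounds. No measurement here explains these steps.

From the compounds shown here alone, it remains open how the ring would read with the amino group alone, with the hydroxy group alone, or with a single methyl group in their place.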